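Trading a branched carbamate for a dipropyl one

The source may report more compounds than this note shows. Statements on the series, on what has been measured and on what is new or still open speak of the compounds shown alone.

Compound 1 `COc1cc(C(=O)N2CCN(C(=O)c3cc(OC)c(OC)c(OC)c3)C(COC(=O)NC(C)C(C)C)C2)cc(OC)c1OC`: 80 nM
Compound 2 `CCC(C)CNC(=O)OCC1CN(C(=O)c2cc(OC)c(OC)c(OC)c2)CCN1C(=O)c1cc(OC)c(OC)c(OC)c1`: 470 nM

In a functional assay (Oryctolagus cuniculus) for inhibition of platelet-activating factor receptor (Cavia porcellus) (on this read-out higher numbers stand for weaker inhibition and lower numbers for stronger inhibition), compound 2 gives 470 nM, the higher of the two numbers, set apart from compound 1 by a 5.9-fold higher number from compound 1 to compound 2 (0.77 log units; beyond the scatter). Compound 3 `CCCN(CCC)C(=O)OCC1CN(C(=O)c2cc(OC)c(OC)c(OC)c2)CCN1C(=O)c1cc(OC)c(OC)c(OC)c1` differs from compound 2 by dipropylamino in place of (2-methylbutyl)amino on a carbonyl carbon, so the hydrogen-bond donor of the carbamate is lost. Within the data shown here, only the step from compound 1 to compound 2 bears on this place, and it changed the chain shape rather than the donor, so no measured step speaks to the change directly. A modest shift toward weaker inhibition is expected, a 1.5-fold higher number from compound 2 to compound 3 (0.17 log units; within the scatter), giving compound 3 an estimated 700 nM within 170 nM to 2800 nM.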

Compound 3, half-maximal inhibitory concentration: 380 nM
Estimate against measurement, compound 3: 1.8-fold (0.27 log units) above; low and high end bracket the measured number.
By their numbers in this assay, from the lowest: compound 1; then compounds 3 and 2 (each within the scatter of the next).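

In this assay, dipropylamino in place of (2-methylbutyl)amino gives a 1.2-fold lower number from compound 2 to compound 3 (0.09 log units; within the scatter) so the hydrogen-bond donor on this carbamate can be lost with no change beyond the scatter for this pair. Dipropylamino in place of (1,2-dimethylpropyl)amino gives a 4.8-fold higher number from compound 1 to compound 3 (0.68 log units; beyond the scatter) and so compound 1, with its (1,2-dimethylpropyl)amino group, stands apart from both other compounds. Nothing measured here explains these numbers. Still open, on these data alone, is how a shorter chain such as diethylamino, or a ring such as piperidin-1-yl, would read out on this carbonyl carbon.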